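The source may report more compounds than this note shows. Statements on the series, on what has been measured and on what is new or still open speak of the compounds shown alone.

Measured in a functional assay on A549 cells (Homo sapiens) for antiproliferative activity, read by MTT assay, with a stated time of 72 h; on this read-out higher numbers stand for weaker inhibition and lower numbers for stronger inhibition:

- compound 1, `COc1cc(-n2cnc3ccc(-c4ccc(C(C)=O)cc4)cc32)cc(OC)c1OC`: 2510 nM
- compound 2, `COc1cc(-n2cnc3ccc(-c4cccc(Cl)c4)cc32)cc(OC)c1OC`: 7050 nM
- compound 3, `COc1cc(-n2cnc3ccc(-c4ccc(Cl)cc4Cl)cc32)cc(OC)c1OC`: only a limit, > 10000 nM

Compound 1 holds the lowest of the two numbers in this assay; the nearest is compound 2, with a 2.8-fold higher number from compound 1 to compound 2 (0.45 log units; beyond the scatter). Compound 3 gives no number, only a limit; see (the limit of > 10000 nM in this assay, at which 1 of the 3 values shown sits). The step to compound 3 is an at least 3.9-fold higher number from compound 1 to compound 3 (0.60 log units; beyond the scatter), while between compound 2 and compound 3 the step is an at least 1.4-fold higher number from compound 2 to compound 3 (0.15 log units; that floor lies within the scatter).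

Compound 4, `COc1cccc(-c2ccc3ncn(-c4cc(OC)c(OC)c(OC)c4)c3c2)c1`, is not yet measured. It differs from compound 1 by 3-methoxyphenyl in place of 4-acetylphenyl on an aromatic carbon. Both measured steps that bear on this change start from the same 4-acetylphenyl and place a singly or doubly halogenated phenyl in its stead: a 2.8-fold higher number from compound 1 to compound 2 (0.45 log units; beyond the scatter) and an at least 3.9-fold higher number from compound 1 to compound 3 (0.60 log units; beyond the scatter), each a weakening. Compound 4 swaps the 4-acetylphenyl for a 3-methoxyphenyl, a singly substituted phenyl as in compound 2. A modest rise in the number in this assay is therefore expected, on the order of the step from compound 1 to compound 2, with the estimated step given as a 2.0-fold higher number from compound 1 to compound 4 (0.30 log units; within the scatter). Compound 4 is estimated at 5000 nM, with a range from 2000 nM to 12000 nM.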

Compound 4, half-maximal inhibitory concentration: 3180 nM
Compound 4: middle estimate off by 1.6-fold (0.20 log units), on the high side; measured number inside the range.
By their numbers in this assay, from the lowest: compounds 1 and 4 (each within the scatter of the next); then compound 2. At a limit, above all of these: compound 3.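

In this assay, the change from 4-acetylphenyl to 3-methoxyphenyl gives a 1.3-fold higher number from compound 1 to compound 4 (0.10 log units; within the scatter), so compound 4 goes against the weakening seen in the earlier replacements of 4-acetylphenyl. The identity of the singly substituted phenyl group also registers at this position, as methoxy in place of chloro gives a 2.2-fold lower number from compound 2 to compound 4 (0.35 log units; beyond the scatter). The series further gives an at least 3.1-fold lower number from compound 3 to compound 4 (0.49 log units; beyond the scatter), which is a floor and not a size, as compound 3 carries only a limit: the limit of > 10000 nM in this assay, at which 1 of the 4 values shown sits.

Compounds 1 and 4 differ in both the substituent and its place on the phenyl ring, and the compounds shown do not separate these two changes. Going by these compounds, how an amine or a carboxylic acid on that phenyl ring would read in this assay also remains open.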